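Inverting One Chain Stereocentre of Compound 2

The source may report more compounds than this note shows. Statements on the series, on what has been measured and on what is new or still open speak of the compounds shown alone.

In an ADME assay on Akata cells (Homo sapiens) for cytotoxicity (a lower number here means that less compound is tolerated, a higher number that more compound is tolerated), compound 1 (`Nc1nc2c(ncn2/C=C2\C[C@@H]2[C@H](O)CO)c(=O)[nH]1`) gives 67000 nM. Its isomer, compound 2 (`Nc1nc2c(ncn2/C=C2/C[C@H]2[C@H](O)CO)c(=O)[nH]1`), gives 62600 nM, so the two compounds stand level within the scatter. Within the data shown here, the one measured step is a 1.1-fold lower number from compound 1 to compound 2 (0.03 log units; within the scatter). It changed a stereocentre at a saturated ring carbon and a double bond, and the fact that compounds 1 and 2 differ only in the configuration as drawn describes the whole of that difference.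

Compound 3 (`Nc1nc2c(ncn2/C=C2/C[C@H]2[C@@H](O)CO)c(=O)[nH]1`) is the next isomer to consider, and its relation to compound 2 is this: the two compounds have the same atoms and bonds and differ only in configuration as drawn: 1 of 3 stereo elements differ; a stereocentre at a saturated chain carbon is drawn S in compound 2 and R in compound 3. Nothing leaves and nothing enters. The saturated chain carbon now inverted was not altered in the measured step, so that step bears on this change only indirectly. Even so, two configurational changes together produced only a 1.1-fold lower number from compound 1 to compound 2 (0.03 log units; within the scatter), and a single further inversion is therefore expected to leave this assay without a step beyond the scatter, in neither direction. The expected change is a 1.0-fold higher number from compound 2 to compound 3 (0.01 log units; within the scatter). The estimated value for compound 3 is 64000 nM, with an expected range from 35000 nM to 115000 nM.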

Compound 3, half-maximal cytotoxic concentration: 78000 nM
The estimate for compound 3 lay 1.2-fold (0.09 log units) below the measured number, and the stated range covers the measured number.
By their numbers in this assay, from the lowest: compounds 2, 1 and 3 (each within the scatter of the next).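

Inverting the saturated chain carbon on its own, a stereocentre left untouched in the earlier pair, gives a 1.2-fold higher number from compound 2 to compound 3 (0.10 log units; within the scatter) in this assay, so this position now has a step of its own and that step stays within the scatter. Compound 1 and compound 3 differ in all three stereo elements, and even this complete change amounts to only a 1.2-fold higher number from compound 1 to compound 3 (0.07 log units; within the scatter). Among these three isomers, no change of configuration moves the number beyond the scatter, and the comparison at this position isolates a single stereocentre: the fact that compounds 2 and 3 differ only in the configuration as drawn

From the compounds shown here alone, the stereocentre at the saturated ring carbon and the double bond have changed only together in these compounds, so what either does alone in this assay remains open. All three compounds also share the same atoms and bonds, which leaves open how the number would respond if an amine or a carboxylic acid replaced the hydroxyl group on the saturated chain carbon, or if a longer chain stood in its place.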